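Compound 3 and the step to compound 4

The source may hold more compounds than are shown below. What is called first, only, known or untested is meant among the compounds shown, and "the series" means these compounds.

In a functional assay on DU-145 cells (Homo sapiens) for cytotoxicity, read by MTT assay (on this read-out lower numbers stand for stronger inhibition and higher numbers for weaker inhibition), compound 3 `CC(=O)OC(C)CO[C@H](CC=C(C)C)C1=CC(=O)c2c(O)ccc(O)c2C1=O` gives 16600 nM and lies within the scatter of compound 1 `CC(=O)OCCO[C@H](CC=C(C)C)C1=CC(=O)c2c(O)ccc(O)c2C1=O` at 15500 nM. Compound 2 `CCCCC(CC(=O)O[C@H](CC=C(C)C)C1=CC(=O)c2c(O)ccc(O)c2C1=O)OC(C)=O` gives 67700 nM which is a higher number than either. Compound 4 `CCCC(C)(O)CC(=O)O[C@H](CC=C(C)C)C1=CC(=O)c2c(O)ccc(O)c2C1=O` carries (2-hydroxy-2-methylpentyl)carbonyl in place of 2-acetoxypropyl on an oxygen on a saturated carbon. Among the measured compounds shown here, the one measured step (a 1.1-fold higher number from compound 1 to compound 3 (0.03 log units; within the scatter)) concerns only a methyl on the departing chain and says little about this exchange. The nearer guide is compound 2 (67700 nM), which also has a carbonyl group on that oxygen. The expected step is upward (a 2.3-fold higher number from compound 3 to compound 4 (0.36 log units; beyond the scatter)) in this assay and remains uncertain in size. For compound 4 the estimate is 38000 nM with an expected range from 15000 nM to 90000 nM in all.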

Compound 4, half-maximal inhibitory concentration: 75000 nM
Compound 4: the middle estimate sits 2.0-fold (0.30 log units) below what was measured; low and high end bracket the measured number.
By their numbers in this assay, from the lowest: compounds 1 and 3 (each within the scatter of the next); then compounds 2 and 4 (each within the scatter of the next).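

In this assay, (2-hydroxy-2-methylpentyl)carbonyl on this oxygen gives a higher number than either 2-acetoxypropyl (a 4.5-fold higher number from compound 3 to compound 4 (0.65 log units; beyond the scatter)) or 2-acetoxyethyl (a 4.8-fold higher number from compound 1 to compound 4 (0.68 log units; beyond the scatter)). With a carbonyl kept on that oxygen, 1-hydroxy-1-methylbutyl in place of 1-acetoxypentyl stays within the scatter (a 1.1-fold higher number from compound 2 to compound 4 (0.04 log units; within the scatter)), so the chain's hydroxy and acetoxy ends do not separate these two compounds. No measurement given here explains these steps.

Still open, on these data alone, is how a carbonyl-linked chain ending in an amine or a carboxylic acid would read at this oxygen.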